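A few compounds are considered here, and "the series" means these few. Any claim that something is new, unique, unknown or untested is made for them only; others in the source may bear on it.

Compound 1 `C=C(Br)C(=O)Nc1ccc(C(=O)/C=C/c2ccc(OC)c(OC)c2)cc1` and compound 2 `C=C(Br)C(=O)Nc1ccc(C(=O)/C=C/c2ccc(OC)c(OC)c2OC)cc1` share one core and carry a bromoacrylamide on it. In a functional assay on FM3A cells (Mus musculus) for antiproliferative activity, with a stated time of 48 h (on this read-out lower numbers stand for stronger inhibition and higher numbers for weaker inhibition), compound 1 gives 1200 nM, and compound 2 gives 530 nM. The change between them, (methoxy in place of hydrogen on an aromatic carbon), produced a 2.3-fold lower number from compound 1 to compound 2 (0.35 log units; beyond the scatter), a step beyond the scatter.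

Compound 3 `Nc1ccc(C(=O)/C=C/c2ccccc2)cc1` stands on a different core with a free amine in place of the bromoacrylamide; how the two cores differ is not broken down here. In this assay compound 3 gives 34000 nM, the highest of the three numbers recorded so far.

Compound 4 `COc1cccc(/C=C/C(=O)c2ccc(N)cc2)c1` has not yet been measured. It differs from compound 3 by methoxy in place of hydrogen on an aromatic carbon. This is the same kind of change as that from compound 1 to compound 2, but not the same: there the methoxy entered ortho to a large group, ortho to a methoxy group and meta to a methoxy group, whereas here it enters meta to a large group. Resting only on the step of a 2.3-fold lower number from compound 1 to compound 2 (0.35 log units; beyond the scatter), a modest lowering is expected, so compound 4 is estimated at a 1.7-fold lower number from compound 3 to compound 4 (0.23 log units; within the scatter), giving an expected value of 20000 nM with a range from 8000 nM to 50000 nM.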

Compound 4, half-maximal inhibitory concentration: 45000 nM
Compound 4: middle estimate off by 2.3-fold (0.35 log units), on the low side, within the range that was stated.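

In this assay, methoxy in place of hydrogen on an aromatic carbon of the core of compound 3 gave a 1.3-fold higher number from compound 3 to compound 4 (0.12 log units; within the scatter), so on this core the change cannot be told from the scatter. Set beside the earlier step, the effect of this kind of change did not carry over from one core to the other: the same change on two cores in this assay, a 2.3-fold lower number (0.35 log units; beyond the scatter) from compound 1 to compound 2 and a 1.3-fold higher number (0.12 log units; within the scatter) from compound 3 to compound 4, 3.0-fold (0.48 log units) apart, beyond the scatter of two such steps. This does not show that the core alone sets the outcome: the two steps also differ in where the methoxy enters and in whether a bromoacrylamide or a free amine is present, and two steps cannot separate these.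

As far as these compounds go, it remains open whether methoxy at another place on the ring of compound 3 would give a step closer to the earlier one. From the compounds shown here alone, it is also open whether a hydroxyl group or a chlorine atom at the place taken by the methoxy in compound 4 would behave differently on either core.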